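The source may report more compounds than this note shows. Statements on the series, on what has been measured and on what is new or still open speak of the compounds shown alone.

In a functional assay on A-375 cells (Homo sapiens) for antiproliferative activity, read by MTT assay, with a stated time of 72 h (a higher number here means a weaker inhibitor, a lower number a stronger inhibitor), compound 1 (`NC1CCc2nc(-c3ccncc3)nc(Nc3cccc(F)c3)c2C1`), drawn without a configuration at a saturated ring carbon, gives 9900 nM and compound 2 (`N[C@@H]1CCc2nc(-c3ccncc3)nc(Nc3cccc(F)c3)c2C1`), drawn R there, gives 10800 nM in the same assay, the two lying within the scatter of each other (a 1.1-fold higher number from compound 1 to compound 2 (0.04 log units; within the scatter)). Compound 3 (`N[C@H]1CCc2nc(-c3ccncc3)nc(Nc3cccc(F)c3)c2C1`) differs from compound 2 only at that stereocentre, which is drawn S (the two compounds have the same atoms and bonds and differ only in configuration as drawn: 1 of 1 stereo elements differ; a stereocentre at a saturated ring carbon is drawn R in compound 2 and S in compound 3). For the measured compounds named here, the only measured step at this stereocentre is the one above, and it concerns the fact that one of compounds 1 and 2 is drawn with a defined configuration and the other without, at the place where they differ alone. Given the size of that step (a 1.1-fold higher number from compound 1 to compound 2 (0.04 log units; within the scatter)), no step beyond the scatter is expected in this assay in either direction. The expected change (a 1.1-fold lower number from compound 2 to compound 3 (0.06 log units; within the scatter)) is small. For compound 3 the estimate is 9500 nM with an expected range from 4500 nM to 20000 nM for such a measurement.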

Compound 3, half-maximal inhibitory concentration: 10700 nM
Beside the measured number, compound 3's estimate is 1.1-fold (0.05 log units) below it; measured number inside the range.
By their numbers in this assay, from the lowest: compounds 1, 3 and 2 (each within the scatter of the next).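

Compounds 2 and 3 give a direct comparison of the two drawn configurations at the saturated ring carbon, and in this assay the step is a 1.0-fold lower number from compound 2 to compound 3 (0.00 log units; within the scatter). Compound 1, drawn without a configuration there, also stays close to the S form, with a 1.1-fold higher number from compound 1 to compound 3 (0.03 log units; within the scatter). Inverting this stereocentre therefore produces no difference that can be read in this assay, and the comparison is a clean one: the fact that compounds 2 and 3 differ only in the configuration as drawn

On these data alone, it remains open whether configuration at this carbon still makes no readable difference when the amine there gives way to a hydroxyl or a carboxylic acid.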